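Cytotoxicity notes: cyano in place of dimethylamino on the chalcone aryl

The compounds below may be only part of what the source reports. "The series", "measured", "known", "first", "only" and "open" are said of these compounds alone.

Compound 2 `CN(C)c1ccc(/C=C/C(=O)c2ccc3c(c2O)C=CC(C)(C)O3)cc1` is the one of the three measured compounds for which only a limit is recorded: in an ADME assay on Vero cells (Chlorocebus sabaeus) for cytotoxicity, read by MTT assay, with a stated time of 72 h (a lower number here means that less compound is tolerated, a higher number that more compound is tolerated), compound 2 gives > 400000 nM, which is a limit of the assay and not a number. Compound 1 `CCOc1ccc(/C=C/C(=O)c2ccc3c(c2O)C=CC(C)(C)O3)cc1` gives 215000 nM in this assay, and compound 3 `CC1(C)C=Cc2c(ccc(C(=O)/C=C/c3ccc(Cl)cc3)c2O)O1` gives 92200 nM. The steps among these are an at least 1.8-fold higher number from compound 1 to compound 2 (0.26 log units; that floor lies within the scatter), a 2.3-fold lower number from compound 1 to compound 3 (0.37 log units; beyond the scatter) and an at least 4.3-fold lower number from compound 2 to compound 3 (0.63 log units; beyond the scatter). Compound 2 thus sits at the limit of > 400000 nM in this assay, at which 1 of the 3 values shown sits, the upper edge of what the series shows.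

Compound 4 `CC1(C)C=Cc2c(ccc(C(=O)/C=C/c3ccc(C#N)cc3)c2O)O1` differs from compound 2 by cyano in place of dimethylamino on an aromatic carbon. Going by the values given here, the step that bears most directly is the one from compound 2 to compound 3, where another small group took the place of dimethylamino on the same aromatic carbon and the number fell by an at least 4.3-fold lower number from compound 2 to compound 3 (0.63 log units; beyond the scatter); the step from compound 1 to compound 3 points the same way with a 2.3-fold lower number from compound 1 to compound 3 (0.37 log units; beyond the scatter). Cyano is therefore expected to move the number downward, beyond the scatter, though its size is uncertain since compound 2 is only a limit. Compound 4 is expected to give 130000 nM in this assay, within 50000 nM to 350000 nM. This would be a step of an at least 3.0-fold lower number from compound 2 to compound 4 (0.48 log units; beyond the scatter), expected to fall clearly below the limit of compound 2.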

Compound 4, half-maximal cytotoxic concentration: 80200 nM
Compound 4: the middle estimate sits 1.6-fold (0.21 log units) above what was measured; low and high end bracket the measured number.
By their numbers in this assay, from the lowest: compounds 4 and 3 (each within the scatter of the next); then compound 1. At a limit, above all of these: compound 2.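

In this assay, going by these compounds alone, the earlier compounds showed only chloro taking the number down from dimethylamino at this aromatic carbon, para to a large group; cyano now does the same (an at least 4.9-fold lower number from compound 2 to compound 4 (0.69 log units; beyond the scatter)), so the drop is no longer tied to a single group. Cyano and chloro cannot be separated here (a 1.1-fold lower number from compound 3 to compound 4 (0.06 log units; within the scatter)), even though they share no atoms, so the two groups sit together as a pair at the low end of the series. Cyano also stands apart from ethoxy (a 2.7-fold lower number from compound 1 to compound 4 (0.43 log units; beyond the scatter)), which places compound 1 clearly above both compound 3 and compound 4, and among these four compounds nothing goes against this grouping of chloro and cyano on one side and ethoxy and dimethylamino on the other.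

On these data alone, whether the grouping holds for other substituents on this carbon, such as a carboxylic acid, a primary amine or a longer alkoxy chain, stays open. The full size of every step out of compound 2 also stays open, since the value of compound 2 is a limit of the assay and not a number: the limit of > 400000 nM in this assay, at which 1 of the 4 values shown sits.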